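Isopropyl for 2-hydroxy-2-methylpropyl on the shared core

The source may report more compounds than this note shows. Statements on the series, on what has been measured and on what is new or still open speak of the compounds shown alone.

In a functional assay on MCF7 cells (Homo sapiens) for inhibition, read by MTT assay, with a stated time of 5 days (a higher number here means a weaker inhibitor, a lower number a stronger inhibitor), compound 1 `Cc1cc(Nc2nc(NCc3ccc(Cl)cc3)nc3[nH]ncc23)n[nH]1` gives 860 nM as its value. Among the measured compounds shown here, compound 2 `Cc1cc(Nc2nc(NCc3ccc(Cl)cc3)nc3c2cnn3CC(C)(C)O)n[nH]1` gives 1940 nM as its value, the higher of the two numbers so far.

The next entry is compound 3 `Cc1cc(Nc2nc(NCc3ccc(Cl)cc3)nc3c2cnn3C(C)C)n[nH]1`, with isopropyl in place of 2-hydroxy-2-methylpropyl on an aromatic nitrogen.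

For the measured compounds named here, one measured step bears on this change: a 2.3-fold higher number from compound 1 to compound 2 (0.35 log units; beyond the scatter) (modest), with 2-hydroxy-2-methylpropyl in place of hydrogen on an aromatic nitrogen. Going by the values given here, that step spans the hydrogen and the larger chain, and the series holds no measured isopropyl compound, so it gives only a weak lean towards a lower number.

Expected in this assay is a 1.3-fold lower number from compound 2 to compound 3 (0.11 log units; within the scatter) as a small move, with no step beyond the scatter expected.

The estimated value for compound 3 is 1500 nM (expected range 600 nM to 3800 nM).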

Compound 3, half-maximal inhibitory concentration: 2040 nM
Compound 3: middle estimate off by 1.4-fold (0.13 log units), on the low side, and the stated range covers the measured number.
By their numbers in this assay, from the lowest: compound 1; then compounds 2 and 3 (each within the scatter of the next).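

In this assay the step to isopropyl gives a 1.1-fold higher number from compound 2 to compound 3 (0.02 log units; within the scatter) so the hydrogen-bond donor and acceptor counted on 2-hydroxy-2-methylpropyl leave with no readable change at this aromatic nitrogen. The step from hydrogen to isopropyl gives a 2.4-fold higher number from compound 1 to compound 3 (0.38 log units; beyond the scatter) and so a second substituent at this position, one without those counted features, also stands apart from compound 1, which places compounds 2 and 3 together on the same side of it. No supporting measurement accounts for either step.

Still open, on these data alone, is whether a cyclopropyl group, a longer alkyl chain or a chain ending in an amine on this nitrogen would stay level with compounds 2 and 3 or return towards compound 1. Also open, as far as these compounds go, is whether the same pattern holds with a different group in place of the 4-chlorobenzyl amine on the shared core.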